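This account rests on a few compounds, and the source may have more. Where it says the series, first, only, none or still open, it means among the compounds named here.

Compound 3 `COc1cc([N+](=O)[O-])ccc1-n1cc(COC2=C(CC=C(C)C)C(=O)c3ccccc3C2=O)nn1` sits second highest of three numbers in an ADME assay on HepG2 cells (Homo sapiens) for cytotoxicity, read by MTT assay, with a stated time of 24 h (on this read-out higher numbers stand for lower toxicity in this test and lower numbers for higher toxicity in this test), with 701000 nM. Compound 1 `CC(C)=CCC1=C(OCc2cn(C3CCNCC3)nn2)C(=O)c2ccccc2C1=O` gives 570000 nM in this assay, and compound 2 `CC(C)=CCC1=C(OCc2cn(-c3cccnc3)nn2)C(=O)c2ccccc2C1=O` gives 1030000 nM in this assay. The three steps between them, a 1.8-fold higher number from compound 1 to compound 2 (0.26 log units; within the scatter), a 1.2-fold higher number from compound 1 to compound 3 (0.09 log units; within the scatter) and a 1.5-fold lower number from compound 2 to compound 3 (0.17 log units; within the scatter), all swap the group on the aromatic nitrogen and all stay within the scatter. Compound 4 `COc1ccc(-n2cc(COC3=C(CC=C(C)C)C(=O)c4ccccc4C3=O)nn2)cc1` differs from compound 3 in the same place: 4-methoxyphenyl in place of 2-methoxy-4-nitrophenyl on an aromatic nitrogen. Since every measured swap at this position left this assay essentially unchanged, no step beyond the scatter is expected here, so compound 4 is expected to show a 1.1-fold higher number from compound 3 to compound 4 (0.03 log units; within the scatter). Compound 4 is therefore estimated at 750000 nM, within a range from 350000 nM to 1500000 nM.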

Compound 4, half-maximal cytotoxic concentration: 200000 nM
For compound 4 the middle estimate is 3.8-fold (0.57 log units) above the measured one; the whole stated range lies above it.
By their numbers in this assay, from the lowest: compound 4; then compounds 1, 3 and 2 (each within the scatter of the next).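

In this assay this position on the aromatic nitrogen is not silent after all: a 3.5-fold lower number from compound 3 to compound 4 (0.54 log units; beyond the scatter), a 5.2-fold lower number from compound 2 to compound 4 (0.71 log units; beyond the scatter) and a 2.9-fold lower number from compound 1 to compound 4 (0.45 log units; beyond the scatter) are all beyond the scatter, so 4-methoxyphenyl gives the lowest number of the four, which here means the highest toxicity in this test. Among the compounds shown here, the earlier swaps among piperidin-4-yl, pyridin-3-yl and 2-methoxy-4-nitrophenyl showed no such step. Nothing measured here accounts for the drop. On these data alone, what stays open is which difference between the two aryl groups matters, since the nitro group leaves and the methoxy group changes place together. A plain phenyl or a 4-nitrophenyl group on the same nitrogen would help separate the two.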